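Triazole substituent: nonyl replaced by arylsulfonylamino on methylene

The source may report more compounds than this note shows. Statements on the series, on what has been measured and on what is new or still open speak of the compounds shown alone.

Measured so far:
Compound 1 `COc1ccccc1-c1cn(C[C@H](O)[C@H]2OC(=O)C(OCc3ccccc3)=C2OCc2ccccc2)nn1`: in a functional assay on HCT-116 cells (Homo sapiens) for antiproliferative activity, read by MTT assay, with a stated time of 72 h (on this read-out lower numbers stand for stronger inhibition and higher numbers for weaker inhibition), compound 1 gives > 100000 nM, a limit of the assay.
Compound 2 `CCCCCCCCCCc1cn(C[C@H](O)[C@H]2OC(=O)C(OCc3ccccc3)=C2OCc2ccccc2)nn1`: in this assay compound 2 gives 28800 nM.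
Compound 3 `CC(C)(C)c1cn(C[C@H](O)[C@H]2OC(=O)C(OCc3ccccc3)=C2OCc2ccccc2)nn1`: in this assay compound 3 gives 28300 nM.

Compound 2 and compound 3 sit within the scatter of each other (a 1.0-fold lower number from compound 2 to compound 3 (0.01 log units; within the scatter)), so decyl and tert-butyl on the aromatic carbon are not distinguishable here. The remaining value, that of compound 1, is only a limit (the limit of > 100000 nM in this assay, at which 1 of the 3 values shown sits).

Compound 4 `O=C1O[C@H]([C@@H](O)Cn2cc(CNS(=O)(=O)c3ccc(Cl)cc3F)nn2)C(OCc2ccccc2)=C1OCc1ccccc1` derives from compound 2 by ((4-chloro-2-fluorophenyl)sulfonyl)amino in place of nonyl on a saturated chain carbon bound to an aromatic carbon. Going by the values given here, the steps that bear on it are an at least 3.4-fold lower number from compound 1 to compound 2 (0.54 log units; beyond the scatter) and an at least 3.5-fold lower number from compound 1 to compound 3 (0.54 log units; beyond the scatter), both running from an aryl group to an alkyl group on the aromatic carbon and both giving at least modest lowerings whose true size is hidden by the limit of compound 1. The change to compound 4 runs the other way, an aryl-containing group entering, though through a sulfonylamino link on the chain carbon rather than directly on the ring, so the measured steps transfer only loosely. A modest rise in number, possibly up to the limit, is expected.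

Compound 4 is estimated at 50000 nM, range 10000 nM to 200000 nM, a step of a 1.7-fold higher number from compound 2 to compound 4 (0.24 log units; within the scatter) expected from compound 2.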

Compound 4, half-maximal inhibitory concentration: 21600 nM
Beside the measured number, compound 4's estimate is 2.3-fold (0.36 log units) above it; measured number inside the range.
By their numbers in this assay, from the lowest: compounds 4, 3 and 2 (each within the scatter of the next). At a limit, above all of these: compound 1.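

Swapping nonyl for ((4-chloro-2-fluorophenyl)sulfonyl)amino on a saturated chain carbon bound to an aromatic carbon leaves the read-out in this assay unchanged within the scatter: a 1.3-fold lower number from compound 2 to compound 4 (0.12 log units; within the scatter). The earlier compounds shown here varied this substituent only among alkyl groups and a 2-methoxyphenyl group, whereas this change removes a purely carbon chain and brings in a sulfonylamino link, an aromatic ring, a hydrogen-bond donor and hydrogen-bond acceptors. An aromatic ring carried on this chain therefore does not by itself rule out a measured number, since compound 4 gives 21600 nM in this assay, although no gain over the nonyl-bearing compound 2 is seen.

From the compounds shown here alone, whether an amine or a carboxylic acid on the same chain carbon, or a phenylsulfonylamino group without chlorine and fluorine, would shift the value beyond the scatter remains open. The size of any gap involving the 2-methoxyphenyl group on the aromatic carbon of compound 1 also stays unread, as compound 1 is held at a limit of the assay: the limit of > 100000 nM in this assay, at which 1 of the 4 values shown sits.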